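Cytotoxicity in MT4 cells across a diaryl ether series

A few compounds are considered here, and "the series" means these few. Any claim that something is new, unique, unknown or untested is made for them only; others in the source may bear on it.

Measured so far:
compound 1 `N#Cc1ccc(Nc2nccc(Oc3ccc(-c4ccc(C#N)cc4)cc3C(F)(F)F)n2)cc1`: > 273000 nM
compound 2 `N#Cc1ccc(Nc2nccc(Oc3ccc(-c4ccc(C#N)cc4Cl)cc3Cl)n2)cc1`: > 273000 nM
compound 3 `N#Cc1ccc(Nc2nccc(Oc3ccc(-c4ccc(C#N)c(Cl)c4)cc3Cl)n2)cc1`: 14900 nM

In a functional assay on MT4 cells (Homo sapiens) for cytotoxicity, read by MTT assay, with a stated time of 5 days (on this read-out lower numbers stand for higher toxicity in this test and higher numbers for lower toxicity in this test), compound 1 gives > 273000 nM, which is a limit of the assay and not a number. Compound 2 likewise gives only the limit > 273000 nM. Among the compounds with values here, compound 3 gives 14900 nM, the only number among the three. Within the data shown here, the single measured step, an at least 18-fold lower number from compound 2 to compound 3 (1.26 log units; beyond the scatter), runs from the limit down to this number, so compound 3 stands as the one member with a measured half-maximal cytotoxic concentration, the other two sitting at the limit (the limit of > 273000 nM in this assay, at which 2 of the 3 values shown sit).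

Compound 4 `N#Cc1ccc(Nc2nccc(Oc3ccc(-c4ccc(C#N)cc4)cc3Cl)n2)cc1` is not yet measured. It differs from compound 3 by hydrogen in place of chloro on an aromatic carbon. Among the measured compounds shown here, no measured step covers exactly this change. Compound 1, which carries the 4-cyanophenyl of compound 4 on a differently substituted middle ring, sits at the limit, and compound 2, with a chloro elsewhere on that terminal ring, sits at the limit too. Only compound 3 gives a number. The removal of the chloro ortho to the cyano group therefore is expected to move the value back toward the limit, an estimated 8.1-fold higher number from compound 3 to compound 4 (0.91 log units; beyond the scatter). Compound 4 is expected at about 120000 nM, in the range 30000 nM to 300000 nM, with a fair chance that only a limit is reported.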

Compound 4, half-maximal cytotoxic concentration: > 295000 nM
Compound 4 ended at the assay's limit; the forecaster's own chance of this, stated with the estimate: 55%; at least 2.4-fold (0.39 log units) between middle value and limit.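

Hydrogen in place of chloro ortho to a cyano group gives an at least 19-fold higher number from compound 3 to compound 4 (1.29 log units; beyond the scatter) in this assay, so this one position carries a large change on the read-out. Compound 4 gives only a limit of the assay, not a number: the limit of > 295000 nM in this assay, at which 1 of the 4 values shown sits. The 4-cyanophenyl of compound 4 thus joins the 2-chloro-4-cyanophenyl of compound 2 without a number, which leaves the 3-chloro-4-cyanophenyl of compound 3 as the only one of the three to give a number, while the steps to compound 4 from compound 1 and from compound 2 cannot be read, as each has a limit at both ends.

As far as these compounds go, whether the number depends on chloro itself at this position stays open, and a fluoro, a methyl or a methoxy group there would address that. Also open, from the compounds shown here alone, is whether the 3-chloro-4-cyanophenyl still gives a number with trifluoromethyl in place of the chloro on the other ring, as in compound 1, or with an amine in place of the cyano group.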